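Second chloro on the benzyl group of compound 3

The source may report more compounds than this note shows. Statements on the series, on what has been measured and on what is new or still open speak of the compounds shown alone.

In a functional assay on NCI-H460 cells (Homo sapiens) for cytotoxicity, read by MTT assay, with a stated time of 72 h (a lower number here means a stronger inhibitor, a higher number a weaker inhibitor), compound 3 `CN(C)Cc1ccc2nc(NC(=O)N/N=C/c3cn(Cc4ccc(Cl)cc4)c4ccccc34)sc2c1` gives 290 nM, the lowest of the three numbers available. Compound 1 `CCN(CC)Cc1ccc2nc(NC(=O)N/N=C/c3cn(Cc4ccc(Cl)cc4Cl)c4ccccc34)sc2c1` comes next at 1080 nM and compound 2 `CN(C)Cc1ccc2nc(NC(=O)N/N=C/c3c[nH]c4ccccc34)sc2c1` lies furthest at 2550 nM, both beyond the scatter from compound 3.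

Compound 4 `CN(C)Cc1ccc2nc(NC(=O)N/N=C/c3cn(Cc4ccc(Cl)cc4Cl)c4ccccc34)sc2c1` differs from compound 3 by chloro in place of hydrogen on an aromatic carbon, turning 4-chlorobenzyl into 2,4-dichlorobenzyl.

For the measured compounds named here, the only measured single-place step is an 8.8-fold lower number from compound 2 to compound 3 (0.94 log units; beyond the scatter), with 4-chlorobenzyl in place of hydrogen on an aromatic nitrogen. It is a larger change and does not measure the added chloro. Compound 1 already carries 2,4-dichlorobenzyl, but its amine differs from that of compound 4, so compound 1 at 1080 nM gives only a loose hint towards a higher number.

In this assay the expected step is small and within the scatter, at a 1.4-fold higher number from compound 3 to compound 4 (0.14 log units; within the scatter). Compound 4 is estimated at 400 nM, with an expected range of 130 nM to 1200 nM.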

Compound 4, half-maximal inhibitory concentration: 950 nM
Beside the measured number, compound 4's estimate is 2.4-fold (0.38 log units) below it, and the stated range covers the measured number.
By their numbers in this assay, from the lowest: compound 3; then compounds 4 and 1 (each within the scatter of the next); then compound 2.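

Adding a chloro ortho to a large group on the 4-chlorobenzyl ring carries a cost in this assay, with a 3.3-fold higher number from compound 3 to compound 4 (0.52 log units; beyond the scatter), so this aromatic carbon does not accept chloro without a change in the number. The 2,4-dichlorobenzyl group still gives a lower number than hydrogen on the aromatic nitrogen, at a 2.7-fold lower number from compound 2 to compound 4 (0.43 log units; beyond the scatter), though this step is smaller than an 8.8-fold lower number from compound 2 to compound 3 (0.94 log units; beyond the scatter). With 2,4-dichlorobenzyl in place, dimethylamino and diethylamino cannot be told apart, at a 1.1-fold lower number from compound 1 to compound 4 (0.06 log units; within the scatter).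

Nothing available explains why the second chloro raises the number. Open questions are whether fluoro or methoxy at this same ortho place would carry the same cost, and whether diethylamino and dimethylamino would also match when paired with 4-chlorobenzyl.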